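The source may hold more compounds than are shown below. What is called first, only, known or untested is meant among the compounds shown, and "the series" means these compounds.

Measured so far:
compound 1 `c1ccc(-c2ccncc2)c(OCC2=NCCN2)c1`, in a functional assay for activation of Alpha-1D adrenergic receptor (Homo sapiens), read by calcium flux; on this read-out higher numbers stand for an effect only at larger amounts of compound and lower numbers for an effect already at smaller amounts < 100000 nM (a limit)
compound 2 `c1cnc(-c2ccccc2OCC2=NCCN2)nc1`, in this assay < 100000 nM (a limit)
compound 3 `c1csc(-c2ccccc2OCC2=NCCN2)c1`, in this assay 15.9 nM

Compound 1 stands only at a limit in this assay, not at a number. Compound 2 likewise sits at a limit. Both share (the limit of < 100000 nM in this assay, at which 2 of the 3 values shown sit), so the steps a step that the two limits leave unreadable from compound 1 to compound 2, a step that the limit leaves unreadable from compound 1 to compound 3 and a step that the limit leaves unreadable from compound 2 to compound 3 cannot be sized; what is known is that compound 3 has a read number and the other two do not.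

Compound 4 `Cc1ccoc1-c1ccccc1OCC1=NCCN1` differs from compound 1 by 3-methylfuran-2-yl in place of pyridin-4-yl on an aromatic carbon. Within the data shown here, the only step that bears on it is the one from compound 1 to compound 3, where a five-membered aromatic ring with one hetero atom enters in place of pyridin-4-yl, and that step is unreadable in size. Since 3-methylfuran-2-yl is again a five-membered aromatic ring with one hetero atom, compound 4 is expected to land near compound 3 rather than at the limit, giving an expected step that the limit leaves unreadable from compound 1 to compound 4. Compound 4 is estimated at 40 nM, with a range of 5 nM to 400 nM.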

Compound 4, half-maximal effective concentration: < 100000 nM
Compound 4 ended at the assay's limit (the forecaster's own chance of this, stated with the estimate: 15%); the middle value lies beyond the limit too.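

In this assay compound 4 gives < 100000 nM, a limit and not a number. No step between compound 4 and compound 1, compound 2 or compound 3 can therefore be read: the limit of < 100000 nM in this assay, at which 3 of the 4 values shown sit.

Left open is how far compound 1, compound 2 and compound 4 actually stand from compound 3.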